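This account rests on a few compounds, and the source may have more. Where it says the series, first, only, none or still open, it means among the compounds named here.

In a functional assay on DU-145 cells (Homo sapiens) for inhibition, read by trypan blue exclusion, with a stated time of 96 h (a lower number here means a stronger inhibitor of growth, a higher number a weaker inhibitor of growth), compound 1 (`O=C(/C(=C\c1ccc([N+](=O)[O-])c(O)c1)S(=O)(=O)c1ccc(Br)cc1)c1c(F)c(F)c(F)c(F)c1F`) gives 1000 nM, compound 2 (`O=C(O)c1cc(/C=C(/Sc2ccc(Br)cc2)C(=O)c2c(F)c(F)c(F)c(F)c2F)ccc1O`) gives 25000 nM, and compound 3 (`O=C(/C(=C\c1ccc([N+](=O)[O-])c(O)c1)SCc1ccc(Br)cc1)c1c(F)c(F)c(F)c(F)c1F`) gives 10000 nM, the second highest of the three numbers. Compound 4 (`O=C(/C(=C\c1ccc([N+](=O)[O-])c(O)c1)Sc1ccc(Br)cc1)c1c(F)c(F)c(F)c(F)c1F`) carries 4-bromophenyl in place of 4-bromobenzyl on a sulfur. Going by the values given here, the only measured step bearing on this group is a 10-fold higher number from compound 1 to compound 3 (1.00 log units; beyond the scatter), a modest one, but it exchanges (4-bromophenyl)sulfonyl for (4-bromobenzyl)sulfanyl and so changes more than the present swap. Compound 2 also holds 4-bromophenyl on sulfur, yet differs elsewhere, so its 25000 nM is only a loose guide. Little change is therefore expected, with no firm direction, and the estimated step is a 1.3-fold lower number from compound 3 to compound 4 (0.10 log units; within the scatter). For compound 4 the expected value is 8000 nM, with an estimated range of 2500 nM to 25000 nM.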

Compound 4, concentration for 50% growth inhibition: 1000 nM
Estimate against measurement, compound 4: 8.0-fold (0.90 log units) above; the measured number lies below the stated range.
By their numbers in this assay, from the lowest: compounds 1 and 4 (each within the scatter of the next); then compound 3; then compound 2.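

In this assay, 4-bromophenyl in place of 4-bromobenzyl on the sulfur matters, giving a 10-fold lower number from compound 3 to compound 4 (1.00 log units; beyond the scatter). With 4-bromophenyl in place, sulfanyl and sulfonyl cannot be told apart, with no change at the digits printed from compound 1 to compound 4 (within the scatter), so a 10-fold higher number from compound 1 to compound 3 (1.00 log units; beyond the scatter) tracks the 4-bromobenzyl group rather than the sulfur's oxidation level. The other aryl group carries the largest step, as 3-hydroxy-4-nitrophenyl in place of 3-carboxy-4-hydroxyphenyl gives a 25-fold lower number from compound 2 to compound 4 (1.40 log units; beyond the scatter). Nothing measured here explains these steps. Going by these compounds, whether a longer chain on the sulfur, or an amine in place of the bromine, would keep these numbers remains open.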